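Methoxy on the anilino ring: a move from compound 1

The source may hold more compounds than are shown below. What is called first, only, known or untested is meant among the compounds shown, and "the series" means these compounds.

Measured compounds:
compound 1, `Cc1nc(SCC(=O)Nc2nc(-c3ccc(Cl)cc3)cs2)n(Nc2ccccc2)c1C`, 16000 nM
compound 2, `Cc1ccc(Nn2c(SCC(=O)Nc3nc(-c4ccccc4)cs3)nc(C)c2C)cc1`, 48600 nM

In a functional assay on M14 cells (Homo sapiens) for antiproliferative activity, read by sulforhodamine B assay, with a stated time of 48 h (on this read-out higher numbers stand for weaker inhibition of growth and lower numbers for stronger inhibition of growth), compound 1 stands lowest of the two numbers; compound 2 lies beyond the scatter above it. Compound 3, `COc1ccc(Nn2c(SCC(=O)Nc3nc(-c4ccc(Cl)cc4)cs3)nc(C)c2C)cc1`, differs from compound 1 by methoxy in place of hydrogen on an aromatic carbon. Among the compounds with values here, no measured pair shows this change, so compound 3 is expected to sit near compound 1, with a step of a 1.3-fold higher number from compound 1 to compound 3 (0.10 log units; within the scatter) not clearly beyond the scatter. The estimate for compound 3 is 20000 nM, within 7000 nM to 60000 nM.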

Compound 3, concentration for total growth inhibition: > 100000 nM
Compound 3: a limit, no number; the forecaster's own chance of this, stated with the estimate: 15%; middle value at least 5.0-fold (0.69 log units) from the limit.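

Replacing phenyl with 4-methoxyphenyl on the anilino group gives an at least 6.2-fold higher number from compound 1 to compound 3 (0.79 log units; beyond the scatter) in this assay, so this position does not accept methoxy without a loss of growth inhibition. The earlier compounds shown here gave no clean reading here, since compound 2 differs from compound 1 in more than one place. The value of compound 3 is a limit and not a number, so the full size of the step stays unknown: the limit of > 100000 nM in this assay, at which 1 of the 3 values shown sits.

Going by these compounds, whether fluorine, a hydroxyl group or an amine at this position would keep the activity of compound 1 remains open.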